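The source may report more compounds than this note shows. Statements on the series, on what has been measured and on what is new or still open speak of the compounds shown alone.

Measured so far in an assay on Sf9 cells for inhibition of protein deacetylase HDAC6 (Homo sapiens), read by fluorescence, with a stated time of 90 min; a lower number here means a stronger inhibitor, a higher number a weaker inhibitor:
Compound 1, `O=C(NO)c1ccc(Cn2c(=O)c(O)c(-c3ccccc3)c3ccccc32)cc1`: 308 nM
Compound 2, `Cn1c(=O)c(OCc2ccc(C(=O)NO)cc2)c(-c2ccccc2)c2ccccc21`: 519 nM

For the measured compounds named here, of these two numbers, compound 2 has the higher one in this assay, and compound 1 is its only neighbour; the gap between the two lies within the usual scatter of repeated measurements, so on this evidence they cannot be told apart. Compound 3, `O=C(NO)c1ccc(COc2c(-c3ccccc3)c3ccccc3n(Cc3ccccc3)c2=O)cc1`, has not yet been measured. It differs from compound 2 in one place: phenyl in place of hydrogen on a saturated chain carbon bound to an aromatic nitrogen. Going by the values given here, no measured pair shows this same change, so there is no step to read from, and the expectation rests only on the nature of the change. A small effect is expected, in either direction, or none beyond the scatter. In this assay the step is expected to be a 1.3-fold lower number from compound 2 to compound 3 (0.11 log units; within the scatter). Compound 3 is estimated at 400 nM, with a range from 150 nM to 1200 nM.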

Compound 3, half-maximal inhibitory concentration: 176 nM
The estimate for compound 3 lay 2.3-fold (0.36 log units) above the measured number; the range from low to high includes it.
By their numbers in this assay, from the lowest: compounds 3, 1 and 2 (each within the scatter of the next, the first and the last beyond it).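

Changing methyl to benzyl on the aromatic nitrogen gives a 2.9-fold lower number from compound 2 to compound 3 (0.47 log units; beyond the scatter) in this assay, a modest step but one beyond the scatter. For the compounds shown here, this is the first direct reading at this position: a saturated chain carbon bound to an aromatic nitrogen accepts phenyl in place of hydrogen, and the number falls rather than rises. Nothing measured here explains the drop.

A single step cannot tell whether the aromatic ring of phenyl matters or whether another group on that carbon, such as cyclohexyl, would give a similar number. It also leaves open whether a longer chain, such as phenethyl in place of benzyl, would lower the number further or raise it again.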